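The source may report more compounds than this note shows. Statements on the series, on what has been measured and on what is new or still open speak of the compounds shown alone.

In a functional assay on MCF7 cells (Homo sapiens) for inhibition, read by MTT assay, with a stated time of 48 h, tested at 10 uM (a higher number here means more inhibition of growth at the concentration tested, a lower number less inhibition of growth), three compounds built on a shared core have been measured. Compound 1 `Cc1cc(=O)c2c(O)c(CN3CCCC3)c(O)c([C@H]3CCN(C)C[C@H]3O)c2o1`, with a pyrrolidin-1-yl group, gives 12%. Compound 2 `Cc1cc(=O)c2c(O)c(CN3CCC(c4ccccc4)CC3)c(O)c([C@H]3CCN(C)C[C@H]3O)c2o1` gives 23%, and compound 3 `Cc1cc(=O)c2c(O)c(CN3CC(O)CC3C(=O)O)c(O)c([C@H]3CCN(C)C[C@H]3O)c2o1`, with a 2-carboxy-4-hydroxypyrrolidin-1-yl group, gives 25%. The value of compound 3 lies within the scatter of that of compound 2 and beyond the scatter from that of compound 1.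

The next compound is compound 4 `Cc1cc(=O)c2c(O)c(CN3CCCCC3)c(O)c([C@H]3CCN(C)C[C@H]3O)c2o1`, which has piperidin-1-yl in place of 2-carboxy-4-hydroxypyrrolidin-1-yl on a saturated chain carbon bound to an aromatic carbon. Within the data shown here, the one measured step that bears on this change is a number 13 percentage points higher from compound 1 to compound 3 (beyond the scatter), modest in size, and it introduces the same group that compound 4 gives up. Read in reverse, it suggests a lower number for compound 4. Among the measured compounds shown here, no measured step isolates the swap from the five-membered to the six-membered ring. Compound 2, which also lacks the departing group, still gives 23%, so a modest fall is expected, one that may stay within the scatter. The expected change is a number 8 percentage points lower from compound 3 to compound 4 (within the scatter). For compound 4 the estimated value is 17%, with an expected range from 7% to 28%.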

Compound 4, percent growth inhibition at one concentration: 15%
Compound 4: middle estimate off by 2 percentage points, on the high side, and the stated range covers the measured number.
By their numbers in this assay, from the lowest: compounds 1, 4, 2 and 3 (each within the scatter of the next, the first and the last beyond it).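

At this place, on a saturated chain carbon bound to an aromatic carbon, the six-membered ring of piperidin-1-yl in place of the five-membered ring of pyrrolidin-1-yl gives a number 3 percentage points higher from compound 1 to compound 4 (within the scatter) in this assay, so these two rings cannot be told apart here. Piperidin-1-yl in place of 2-carboxy-4-hydroxypyrrolidin-1-yl gives a number 10 percentage points lower from compound 3 to compound 4 (within the scatter), and hydrogen in place of phenyl on a saturated ring carbon gives a number 8 percentage points lower from compound 2 to compound 4 (within the scatter), so neither change can be read on its own, and compound 4 sits within the scatter of all three earlier compounds, including the two that lie beyond the scatter of each other. No separate evidence is available to explain these numbers.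

Going by these compounds, it remains open whether the carboxylic acid or the hydroxyl of 2-carboxy-4-hydroxypyrrolidin-1-yl carries a number 13 percentage points higher from compound 1 to compound 3 (beyond the scatter), which a pyrrolidine bearing only one of the two would separate. On these data alone, it is also open whether a morpholin-4-yl group or an open-chain dimethylamino group at this place would give a number beyond the scatter of compound 4.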